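The source may report more compounds than this note shows. Statements on the series, on what has been measured and on what is new or still open speak of the compounds shown alone.

Compound 1 `N#CC1=C(N)Oc2c(c3nc4ccccc4nc3c3ccccc23)C12C(=O)N(Cc1cnnn1-c1ccccc1Br)c1ccccc12`: in an ADME assay on L02 cells (Homo sapiens) for antiproliferative activity, read by MTT assay, with a stated time of 48 h (a higher number here means a weaker inhibitor, a lower number a stronger inhibitor), compound 1 reaches only a limit, > 50000 nM.
Compound 2 `CCOc1ccccc1-n1nncc1CN1C(=O)C2(C(C#N)=C(N)Oc3c2c2nc4ccccc4nc2c2ccccc32)c2ccccc21`: in this assay compound 2 likewise gives only a limit, > 50000 nM.
Compound 3 `Cc1cccc(-n2nncc2CN2C(=O)C3(C(C#N)=C(N)Oc4c(N)cc5nc6ccccc6nc5c43)c3ccccc32)c1`: in this assay compound 3 also stops at a limit, > 50000 nM.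

Compound 3 therefore has no number of its own in this assay, only the limit, and the two companions it is measured beside stand at the same limit; nothing among the shown values separates it from them. Within the data shown here, the one step between measured compounds, a step that the two limits leave unreadable from compound 1 to compound 2, changes the group on the phenyl ring of the triazole but cannot be sized, since both ends are limits.

Compound 4 `N#CC1=C(N)Oc2c(N)cc3nc4ccccc4nc3c2C12C(=O)N(Cc1cnnn1-c1ccccc1Cl)c1ccccc12` differs from compound 3 in one place: 2-chlorophenyl in place of 3-methylphenyl on an aromatic nitrogen. Among the measured compounds shown here, no measured step bears directly on this exchange. What the data offer is the limit of > 50000 nM in this assay, at which 3 of the 3 values shown sit, and because every measured compound sits at the limit of > 50000 nM in this assay, at which 3 of the 3 values shown sit, the expectation is that compound 4 too will reach no number in this assay. The step from compound 3 to compound 4 is estimated as a step that the limit leaves unreadable from compound 3 to compound 4, which is to say none that the assay could read. Compound 4 is expected at 80000 nM in this assay, within a range from 40000 nM to 250000 nM, most probably reported again as a limit.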

Compound 4, half-maximal inhibitory concentration: > 50000 nM
Compound 4: only a limit was reported; the forecaster's own chance of this, stated with the estimate: 85%; the middle value lies beyond the limit too.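

In this assay compound 4 gives only a limit, > 50000 nM. No step can be read between compound 3 and compound 4, as neither has a number of its own. The compounds shown leave open what value these structures would reach in this assay, and whether the group on the aromatic nitrogen matters there at all: the limit of > 50000 nM in this assay, at which 4 of the 4 values shown sit.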